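A few compounds are considered here, and "the series" means these few. Any claim that something is new, unique, unknown or untested is made for them only; others in the source may bear on it.

Compound 1 `O=c1cc(-c2ccccc2)c2ccc(OCC(O)CN3CCNCC3)cc2o1`: 0.0058 ug/mL
Compound 2 `O=c1cc(-c2ccccc2)c2ccc(OCC(O)CN3CCN(c4ccccc4)CC3)cc2o1`: 0.0054 ug/mL

In a functional assay on ileum for antagonist activity at histamine H1 receptor (Cavia porcellus), tested at 0.1 mg/mL (on this read-out higher numbers stand for an effect only at larger amounts of compound and lower numbers for an effect already at smaller amounts), compound 2 stands at one end of these two numbers, but its gap to compound 1 is within the scatter: a 1.1-fold lower number from compound 1 to compound 2 (0.03 log units; within the scatter). Compound 3 `COc1ccccc1N1CCN(CC(O)COc2ccc3c(-c4ccccc4)cc(=O)oc3c2)CC1` carries methoxy in place of hydrogen on an aromatic carbon. For the measured compounds named here, no measured step bears directly on this change; the only step available altered a different part of the molecule and hardly moved the number. Compound 3 is therefore expected to stay close to compound 2. The expected step is a 1.0-fold higher number from compound 2 to compound 3 (0.01 log units; within the scatter). The estimate for compound 3 in this assay is 0.0055 ug/mL, within 0.002 ug/mL to 0.015 ug/mL.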

Compound 3, half-maximal effective concentration: 0.0057 ug/mL
The estimate for compound 3 lay 1.0-fold (0.02 log units) below the measured number; the range from low to high includes it.
By their numbers in this assay, from the lowest: compounds 2, 3 and 1 (each within the scatter of the next).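

In this assay, the phenyl ring tolerates methoxy on an aromatic carbon, ortho to a large group, with the number staying within the scatter: a 1.1-fold higher number from compound 2 to compound 3 (0.02 log units; within the scatter). The earlier compounds shown here covered only bare phenyl on the ring amine nitrogen; the same holds for 2-methoxyphenyl in place of that hydrogen, with a 1.0-fold lower number from compound 1 to compound 3 (0.01 log units; within the scatter). No measurement at hand explains why these numbers stay level. From the compounds shown here alone, whether this holds for methoxy elsewhere on the phenyl stays open, as does the outcome with a carboxylic acid or an amine there.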